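The compounds below may be only part of what the source reports. "The series", "measured", "known", "first", "only" and "open" are said of these compounds alone.

Of the compounds shown here, two have numbers so far. Compound 1 `Cc1cccc(-c2noc([C@@H](C)NC(=O)c3cc(C4CC4)nn3C)n2)c1` gives 3310 nM in an assay on T-REx-293 cells for inhibition of potassium channel subfamily T member 1 (Homo sapiens), read by patch clamp; a higher number here means a weaker inhibitor, a lower number a stronger inhibitor. Compound 2 `Cc1ccnc(-c2noc([C@H](C)NC(=O)c3cc(C(F)(F)F)nn3C)n2)c1` gives 4470 nM in this assay; its number and that of compound 1 fall within the usual scatter of each other, so the two cannot be told apart on these data, and nothing beyond this pair is known about the series.

Compound 3 `C[C@H](NC(=O)c1cc(C(F)(F)F)nn1C)c1nc(-c2ccnc(N(C)C)c2)no1` has not been measured. It differs from compound 2 in one place: 2-(dimethylamino)pyridin-4-yl in place of 4-methylpyridin-2-yl on an aromatic carbon. Among the compounds with values here, no measured pair in the set shows a comparable change, so the effect of this change is unknown. Within the data shown here, with no precedent, the expected step is none beyond the scatter, and the step from compound 2 to compound 3 is estimated as a 1.1-fold lower number from compound 2 to compound 3 (0.05 log units; within the scatter). Compound 3 is therefore expected to give about 4000 nM in this assay, with a range from 1400 nM to 11000 nM.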

Compound 3, half-maximal inhibitory concentration: 454 nM
Estimate against measurement, compound 3: 8.8-fold (0.95 log units) above; the measured number lies below the stated range.
By their numbers in this assay, from the lowest: compound 3; then compounds 1 and 2 (each within the scatter of the next).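

This position, on an aromatic carbon of the five-membered ring between two ring nitrogen atoms, is not indifferent in this assay: 2-(dimethylamino)pyridin-4-yl in place of 4-methylpyridin-2-yl gives a 9.8-fold lower number from compound 2 to compound 3 (0.99 log units; beyond the scatter) with the rest of the molecule unchanged. Within the data shown here, the earlier pair differs in more than one place and could not isolate the contribution of any single position, so this is the first one-place reading. The data at hand offer no measurement that accounts for the size of this step.

The change alters both the substituent and the pyridine attachment, and the compounds shown do not separate the two. Also open, going by these compounds, is whether a methylamino group, a morpholine or a methoxy group on the pyridin-4-yl ring would keep the lower number.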